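The source may hold more compounds than are shown below. What is called first, only, known or untested is meant among the compounds shown, and "the series" means these compounds.

Measured compounds:
Compound 1 `CCn1c(/C=C2/C(=O)Nc3ccc(Br)cc32)nc2ccccc21`: in a functional assay on A549 cells (Homo sapiens) for cytotoxicity, read by MTT assay, with a stated time of 48 h (a higher number here means a weaker inhibitor, a lower number a stronger inhibitor), compound 1 gives > 50000 nM, a limit of the assay rather than a number.
Compound 2 `Cn1c(/C=C2/C(=O)Nc3ccc(Br)cc32)nc2ccccc21`: in this assay compound 2 gives 41200 nM.
Compound 3 `CC(C)n1c(/C=C2/C(=O)Nc3ccc(Cl)cc32)nc2ccccc21`: in this assay compound 3 gives 35200 nM.

Compound 2 holds the highest of the two numbers in this assay; compound 3 sits within the scatter of it, and compound 1 is a limit (the limit of > 50000 nM in this assay, at which 1 of the 3 values shown sits). For the measured compounds named here, the only measured step, an at least 1.2-fold lower number from compound 1 to compound 2 (0.08 log units; that floor lies within the scatter), concerns the chain on the aromatic nitrogen and carries no information about the halogen on the fused ring. Compound 4 `Cn1c(/C=C2/C(=O)Nc3ccc(F)cc32)nc2ccccc21` differs from compound 2 by fluoro in place of bromo on an aromatic carbon. Going by the values given here, with no comparable step in hand, no shift beyond the scatter is expected in this assay for compound 4, and the outcome may again be a limit. Compound 4 is estimated at 45000 nM, range 20000 nM to 100000 nM, an expected step of a 1.1-fold higher number from compound 2 to compound 4 (0.04 log units; within the scatter).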

Compound 4, half-maximal inhibitory concentration: 34600 nM
Compound 4: the middle estimate sits 1.3-fold (0.11 log units) above what was measured; the range from low to high includes it.
By their numbers in this assay, from the lowest: compounds 4, 3 and 2 (each within the scatter of the next). At a limit, above all of these: compound 1.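

In this assay, the first step read at this aromatic carbon is a 1.2-fold lower number from compound 2 to compound 4 (0.08 log units; within the scatter), so with the methyl chain on the aromatic nitrogen held fixed, exchanging bromo for fluoro leaves the number unchanged within the scatter. Between these two halogens, this position shows no readable preference. Nothing shown bears on a cause for this step.

From the compounds shown here alone, whether an amine, a carboxylic acid or a methoxy group at this position would move the number beyond the scatter remains open. So does whether the fluoro result holds with a longer chain on the aromatic nitrogen.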